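Shortening the Saturated Chain and Tolerated Concentration on HEL Cells

The source may report more compounds than this note shows. Statements on the series, on what has been measured and on what is new or still open speak of the compounds shown alone.

Compound 1 `CCCCCCCCCCCc1cc2cn(COCCO)c(O)nc-2n1` carries a long saturated chain on the shared core. In a functional assay on HEL cells (Homo sapiens), read by microscopy (a lower number here means that less compound is tolerated, a higher number that more compound is tolerated), compound 1 gives 80000 nM. Compound 2 `CCCCCCCCc1cc2cn(COCCO)c(O)nc-2n1` has the same core with a shorter chain, and in this assay compound 2 gives 80000 nM. The step of no change at the digits printed from compound 1 to compound 2 (within the scatter) shows nothing beyond the scatter, so compound 2 stands level with compound 1 at the digits shown. Compound 3 `CCCCCc1cc2cn(COCCO)c(O)nc-2n1` continues along the same line; it differs from compound 2 by hydrogen in place of propyl on a saturated chain carbon, five bonds along the chain from an aromatic carbon. For the measured compounds named here, the only measured step that bears on this change is no change at the digits printed from compound 1 to compound 2 (within the scatter), which was flat. With a single flat step to go on, no movement beyond the scatter is expected in this assay for compound 3. Compound 3 is therefore expected to give 80000 nM in this assay, with a range from 40000 nM to 160000 nM. The step of no change at the digits printed from compound 2 to compound 3 (within the scatter) implied by this estimate is expected to be none beyond the scatter.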

Compound 3, minimum cytotoxic concentration: > 400000 nM
Compound 3 ended at the assay's limit (the forecaster's own chance of this, stated with the estimate: 20%); middle value at least 5.0-fold (0.69 log units) from the limit.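

Along this chain the same change does not always give the same result: hydrogen in place of propyl, eight bonds along the chain from an aromatic carbon, gave no change at the digits printed from compound 1 to compound 2 (within the scatter), whereas five bonds along it gives an at least 5.0-fold higher number from compound 2 to compound 3 (0.69 log units; beyond the scatter). Taken as a single change, hydrogen in place of hexyl at this place gives an at least 5.0-fold higher number from compound 1 to compound 3 (0.69 log units; beyond the scatter), so the shift in this assay appears only once the chain has been cut back to the length in compound 3. Compound 3 gives > 400000 nM, which is a limit of the assay and not a number: the limit of > 400000 nM in this assay, at which 1 of the 3 values shown sits.

The compounds shown leave open how far the tolerated concentration lies beyond this limit and at which chain length between compound 2 and compound 3 the shift sets in. They also leave open whether a still shorter chain, or a chain ending in an amine or a carboxylic acid, would read the same way.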